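Replacing an arylmethyl thioether with a hexyl chain

The source may hold more compounds than are shown below. What is called first, only, known or untested is meant among the compounds shown, and "the series" means these compounds.

Measured compounds:
- compound 1, `O=c1c2ccccc2[se]n1-c1nc(SCc2ccccc2)n[nH]1`: > 50000 nM
- compound 2, `CCSc1n[nH]c(-n2[se]c3ccccc3c2=O)n1`: 35200 nM
- compound 3, `Cc1ccccc1CSc1n[nH]c(-n2[se]c3ccccc3c2=O)n1`: 15600 nM

All three share one core and differ only in the group attached through sulfur. In an ADME assay on L929 cells (Mus musculus) for antiproliferative activity, read by CCK-8 assay, with a stated time of 48 h (a higher number here means a weaker inhibitor, a lower number a stronger inhibitor), compound 3 gives 15600 nM, the lowest number of the two that were measured as numbers. Compound 2 gives 35200 nM in this assay. For compound 1 the assay reports only a limit, > 50000 nM, at which one of the three values sits (the limit of > 50000 nM in this assay, at which 1 of the 3 values shown sits). The steps are an at least 1.4-fold lower number from compound 1 to compound 2 (0.15 log units; that floor lies within the scatter), an at least 3.2-fold lower number from compound 1 to compound 3 (0.50 log units; beyond the scatter) and a 2.3-fold lower number from compound 2 to compound 3 (0.35 log units; beyond the scatter).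

Compound 4, `CCCCCCSc1n[nH]c(-n2[se]c3ccccc3c2=O)n1`, is not yet measured. It differs from compound 3 as follows: pentyl in place of 2-methylphenyl on a saturated chain carbon bound to a sulfur. The step that bears most on this is a 2.3-fold lower number from compound 2 to compound 3 (0.35 log units; beyond the scatter), in which a longer, ring-bearing group gave a lower number than a short chain. Compound 4 carries a chain longer than that of compound 2 but no ring, so a number between those of compound 2 and compound 3 is expected, with a risk that it lands at the limit as for compound 1. For compound 4 the estimate in this assay is 25000 nM, spanning 10000 nM to 60000 nM, which is an expected step of a 1.6-fold higher number from compound 3 to compound 4 (0.20 log units; within the scatter).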

Compound 4, half-maximal inhibitory concentration: 39300 nM
The estimate for compound 4 lay 1.6-fold (0.20 log units) below the measured number; measured number inside the range.
By their numbers in this assay, from the lowest: compound 3; then compounds 2 and 4 (each within the scatter of the next). At a limit, above all of these: compound 1.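

In this assay the ring-bearing group of compound 3 cannot be exchanged for a plain chain without loss: putting hexyl in place of 2-methylbenzyl gives a 2.5-fold higher number from compound 3 to compound 4 (0.40 log units; beyond the scatter) and so leaves compound 3 with the lowest number of the set. Chain length alone does not recover that number, since going from the short chain of compound 2 to the hexyl chain gives a 1.1-fold higher number from compound 2 to compound 4 (0.05 log units; within the scatter) and the two compounds cannot be told apart. Compound 1 goes against any simple rule that a ring at this position is enough, because it also carries a phenyl ring there yet has only a limit, which leaves an at least 1.2-fold lower number from compound 1 to compound 4 (0.10 log units; that floor lies within the scatter) as a floor and not a measured size: the limit of > 50000 nM in this assay, at which 1 of the 4 values shown sits.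

A cyclohexylmethyl group on the sulfur would show whether a saturated ring can do what the 2-methylbenzyl group does. On these data alone, it also remains open whether the methyl of compound 3 could be replaced by a chlorine or a methoxy group, or whether a hydroxyl or an amine at the end of the hexyl chain would change the number.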